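Compound 3 against a solubility limit

The compounds below may be only part of what the source reports. "The series", "measured", "known", "first", "only" and "open" are said of these compounds alone.

In a physicochemical assay for solubility, using the shake flask method, in simulated intestinal fluid, measured as kinetic solubility, with a stated time of 2 h, at 25 degrees C, at pH 6.5 (a lower number here means a less soluble compound, a higher number a more soluble compound), compound 1 `Cc1noc(-c2nc(C)c3c(c2N)C(=O)N(Cc2ccc(Br)cc2)C3=O)n1` gives < 5000 nM, which is a limit of the assay and not a number. Compound 2 `Cc1noc(-c2nc(C)c3c(c2N)C(=O)N(Cc2cccc(C(F)(F)F)c2)C3=O)n1` stands at < 5000 nM in this assay, again a limit and not a number, so its position is known only as a limit. The evidence so far is the limit of < 5000 nM in this assay, at which 2 of the 2 values shown sit.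

Compound 3 `Cc1noc(-c2nc(C)c3c(c2N)C(=O)N(Cc2ccccc2F)C3=O)n1` carries 2-fluorophenyl in place of 3-(trifluoromethyl)phenyl on a saturated chain carbon bound to an amide-type nitrogen in a ring.

Within the data shown here, the one measured step that bears on this change sits at the same place, and it is a step that the two limits leave unreadable from compound 1 to compound 2. It offers neither a size nor a direction to carry forward, so no step beyond the scatter is expected in this assay. The estimated change is a step that the limit leaves unreadable from compound 2 to compound 3, with no direction argued for it. Another report as a limit is the most likely outcome. The estimated solubility of compound 3 is 3000 nM, with an expected range from 1000 nM to 6000 nM.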

Compound 3, solubility: < 5000 nM
Compound 3: only a limit was reported; the forecaster's own chance of this, stated with the estimate: 80%; the middle value is on the limit's open side.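

In this assay compound 3 gives < 5000 nM, a limit of the assay and not a number. The steps to compound 3 from compound 1 and compound 2 join limits only, so no new step can be read from them. The compounds shown leave open whether 4-bromophenyl, 3-(trifluoromethyl)phenyl and 2-fluorophenyl differ at all in this assay.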